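Cyano for fluoro on the aryl ring of a dienone series

A few compounds are considered here, and "the series" means these few. Any claim that something is new, unique, unknown or untested is made for them only; others in the source may bear on it.

Measured compounds:
- compound 1, `CC1=C(/C=C/C(=O)/C=C/c2ccccc2)C(C)(C)CCC1O`: 15500 nM
- compound 2, `CC1=C(/C=C/C(=O)/C=C/c2cccc(C(F)(F)F)c2)C(C)(C)CCC1O`: 3500 nM
- compound 3, `CC1=C(/C=C/C(=O)/C=C/c2ccc(F)cc2)C(C)(C)CCC1O`: 6200 nM

In a functional assay on PC-3 cells (Homo sapiens) for cytotoxicity, read by MTT assay, with a stated time of 72 h (a lower number here means a stronger inhibitor, a higher number a weaker inhibitor), compound 3 holds the second highest of the three numbers; its gap to compound 2 lies within the scatter, while compound 1 sits further away. The unmeasured compound 4, `CC1=C(/C=C/C(=O)/C=C/c2cccc(C#N)c2)C(C)(C)CCC1O`, differs from compound 3 by 3-cyanophenyl in place of 4-fluorophenyl on a double-bonded chain carbon bound to a double-bonded chain carbon. Among the measured compounds shown here, no measured step covers this exact swap. The two steps that bear on it both start from the unsubstituted ring of compound 1: a 4.4-fold lower number from compound 1 to compound 2 (0.65 log units; beyond the scatter) and a 2.5-fold lower number from compound 1 to compound 3 (0.40 log units; beyond the scatter). Both substituents give a modest drop, and the two substituted compounds 2 and 3 end within the scatter of each other. A nitrile on the ring is therefore expected to land in the same region as compound 2 and compound 3, so in this assay the step of a 1.4-fold lower number from compound 3 to compound 4 (0.14 log units; within the scatter) is expected to be none beyond the scatter. Compound 4 is estimated at 4500 nM, within 2000 nM to 11000 nM.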

Compound 4, half-maximal inhibitory concentration: 7200 nM
For compound 4 the middle estimate is 1.6-fold (0.20 log units) below the measured one; low and high end bracket the measured number.
By their numbers in this assay, from the lowest: compounds 2, 3 and 4 (each within the scatter of the next, the first and the last beyond it); then compound 1.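

In this assay, 3-cyanophenyl in place of 4-fluorophenyl on this chain carbon gives a 1.2-fold higher number from compound 3 to compound 4 (0.06 log units; within the scatter), while the nitrile still keeps a separation from the unsubstituted ring, with a 2.2-fold lower number from compound 1 to compound 4 (0.33 log units; beyond the scatter). Cyano in place of trifluoromethyl on an aromatic carbon gives a 2.1-fold higher number from compound 2 to compound 4 (0.31 log units; beyond the scatter), a modest step that shows the substituted rings are not all interchangeable here, even though compound 4 stays within the scatter of compound 3. No supporting data are available to explain these differences.

From the compounds shown here alone, whether an amine or a carboxylic acid on the aryl ring would stay in the range of compound 2, compound 3 and compound 4 remains open. Going by these compounds, all four compounds carry the same core, so the effect of any change outside the aryl ring also remains open.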